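Swapping the pyrazole substituent on a MNK1/2 inhibitor scaffold

The source may hold more compounds than are shown below. What is called first, only, known or untested is meant among the compounds shown, and "the series" means these compounds.

Measured so far:
compound 1, `CC(C)Oc1cc(-c2cncc(-c3c[nH]nc3C3CC3)c2)ccc1C(N)=O` — 370 nM
compound 2, `CC(C)Oc1cc(-c2cncc(-c3cnn(C)c3)c2)ccc1C(N)=O` — 750 nM

In an assay on HeLa cells for inhibition of MAP kinase-interacting serine/threonine-protein kinase 1/2 (Homo sapiens), read by AlphaScreen, with a stated time of 2 h (a lower number here means a stronger inhibitor, a higher number a weaker inhibitor), compound 1 gives 370 nM, the lowest of the two numbers shown. Its nearest neighbour is compound 2, at 750 nM in this assay; the change is a 2.0-fold higher number from compound 1 to compound 2 (0.31 log units; beyond the scatter), a modest weakening when 1-methyl-1H-pyrazol-4-yl replaces 3-cyclopropyl-1H-pyrazol-4-yl on an aromatic carbon.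

Compound 3, `Cc1c(-c2cncc(-c3ccc(C(N)=O)c(OC(C)C)c3)c2)cnn1C`, is not yet measured. It differs from compound 1 as follows: 1,5-dimethyl-1H-pyrazol-4-yl in place of 3-cyclopropyl-1H-pyrazol-4-yl on an aromatic carbon. For the measured compounds named here, as in compound 2, the cyclopropyl and the single hydrogen-bond donor of compound 1 are gone, but the entering group here is 1,5-dimethyl-1H-pyrazol-4-yl rather than 1-methyl-1H-pyrazol-4-yl. Going by the values given here, the only step that bears on the question is a 2.0-fold higher number from compound 1 to compound 2 (0.31 log units; beyond the scatter), so a loss of similar size is expected for compound 3, though the second methyl leaves room for it to land anywhere from level with compound 1 to slightly beyond compound 2. For compound 3 in this assay the estimate is 550 nM, within 220 nM to 1400 nM. The expected step is a 1.5-fold higher number from compound 1 to compound 3 (0.17 log units; within the scatter).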

Compound 3, half-maximal inhibitory concentration: 2200 nM
The estimate for compound 3 lay 4.0-fold (0.60 log units) below the measured number; the whole stated range lies below it.
By their numbers in this assay, from the lowest: compound 1; then compound 2; then compound 3.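

In this assay, for the compounds shown here, the single change of methyl in place of hydrogen on an aromatic carbon gives a 2.9-fold higher number from compound 2 to compound 3 (0.47 log units; beyond the scatter), so this part of the pyrazole is sensitive to even the smallest added carbon group, which the first pair could not show. The whole exchange of 3-cyclopropyl-1H-pyrazol-4-yl for 1,5-dimethyl-1H-pyrazol-4-yl gives a 5.9-fold higher number from compound 1 to compound 3 (0.77 log units; beyond the scatter), a larger loss than a 2.0-fold higher number from compound 1 to compound 2 (0.31 log units; beyond the scatter), and it shows that a carbon substituent on this ring does not behave the same way in every setting, since compound 1 carries a cyclopropyl there and remains the lowest of the three. Nothing shown explains why the added methyl costs so much.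

The compounds shown leave open whether the methyl is unfavourable in itself or only alongside the methyl on the ring nitrogen, a question that 3-methyl-1H-pyrazol-4-yl, with its ring nitrogen still bearing hydrogen, would address. They also leave open how the cyclopropyl and the ring-nitrogen hydrogen of compound 1 each contribute, which 3-cyclopropyl-1-methyl-1H-pyrazol-4-yl or the unsubstituted 1H-pyrazol-4-yl would begin to separate.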